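Alkoxy variation on the aminoquinoline core against MCH receptor 1

A few compounds are considered here, and "the series" means these few. Any claim that something is new, unique, unknown or untested is made for them only; others in the source may bear on it.

Measured compounds:
compound 1 `Nc1ccc2cccc(OCCC(F)(F)F)c2n1`: 722 nM
compound 2 `CC(C)Oc1cccc2ccc(N)nc12`: 437 nM
compound 3 `CCCCOc1cccc2ccc(N)nc12`: 789 nM

In an assay on cells with melanin-concentrating hormone receptor 1 (Homo sapiens) as the target, read by radioligand binding (on this read-out higher numbers stand for weaker inhibition and lower numbers for stronger inhibition), compound 3 gives the highest of the three numbers, but its gap to each neighbour is within the scatter: a 1.1-fold higher number from compound 1 to compound 3 (0.04 log units; within the scatter) and a 1.8-fold higher number from compound 2 to compound 3 (0.26 log units; within the scatter). The third comparison, a 1.7-fold lower number from compound 1 to compound 2 (0.22 log units; within the scatter), is likewise within the scatter. Across these three ethers on the shared core, no change beyond the scatter has appeared.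

Going by the values given here, compound 4 `CC(C)C(C)Oc1cccc2ccc(N)nc12` is the next step. 1,2-dimethylpropyl in place of butyl on an oxygen on an aromatic ring The nearest precedent is a 1.8-fold higher number from compound 2 to compound 3 (0.26 log units; within the scatter), where a branched group was replaced by a straight one; that step stayed within the scatter. The change to compound 4 returns to a branched group, larger by one carbon. On this evidence no step beyond the scatter is expected in this assay; if anything, a slight fall toward the number of compound 2 is expected, a 1.3-fold lower number from compound 3 to compound 4 (0.12 log units; within the scatter). Compound 4 is therefore estimated at 600 nM, with a range of 250 nM to 1500 nM.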

Compound 4, half-maximal inhibitory concentration: 199 nM
For compound 4 the middle estimate is 3.0-fold (0.48 log units) above the measured one; the measured number lies below the stated range.
By their numbers in this assay, from the lowest: compound 4; then compounds 2, 1 and 3 (each within the scatter of the next).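

In this assay the group on the oxygen on the aromatic ring produces its first steps beyond the scatter with 1,2-dimethylpropyl, all modest: a 4.0-fold lower number from compound 3 to compound 4 (0.60 log units; beyond the scatter) and a 2.2-fold lower number from compound 2 to compound 4 (0.34 log units; beyond the scatter) and a 3.6-fold lower number from compound 1 to compound 4 (0.56 log units; beyond the scatter) on the shared core. Branching alone does not set compound 4 apart, since compound 2 also carries a branched group and stays within the scatter of compound 1 and compound 3, whereas isopropyl in place of methyl on the chain carbon bound to the oxygen moves the number beyond it. No measurement shown here bears on the reason for these steps.

The compounds shown leave open whether the lower number depends on the methyl or the isopropyl on that chain carbon, which a sec-butyl or an isobutyl group would separate. On these data alone, whether a cyclopentyl or cyclohexyl ring on the same oxygen continues the trend also remains open.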